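The compounds below may be only part of what the source reports. "The series", "measured", "known", "first", "only" and "open" are said of these compounds alone.

Measured to date, in an assay on isolated protein for binding affinity to C-X-C chemokine receptor type 1 (Homo sapiens); on this read-out lower numbers stand for stronger inhibition and higher numbers for weaker inhibition:
- compound 1 `CC[C@@H](Nc1n[s+]([O-])nc1Nc1cccc(C(=O)N(C)C)c1O)c1ccc(C)o1`: 234 nM
- compound 2 `CC[C@@H](NC1=NS(=O)(=O)N=C1Nc1cccc(C(=O)N(C)C)c1O)c1ccccc1`: 8990 nM

Compound 2 stands at the highest of the two numbers; its nearest neighbour is compound 1, whose value sits well beyond the scatter below it. The two compounds differ at more than one place, so the gap between them cannot be assigned to a single change; it only shows that the two values are far apart.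

Compound 3 `CC[C@@H](NC1=NS(=O)(=O)N=C1Nc1cccc(C(=O)N(C)C)c1O)c1ccc(C)o1` keeps the core of compound 2 and carries the change (5-methylfuran-2-yl in place of phenyl on a saturated chain carbon bound to an amine nitrogen and a saturated chain carbon), which is the aryl group of compound 1 on the core of compound 2. Within the data shown here, no pair of measured compounds isolates this exchange, so the direction of the step is taken from the fact that compound 1, which carries this group, gives the lower number. Compound 3 is estimated to move toward the lower number, with a step of a 3.6-fold lower number from compound 2 to compound 3 (0.56 log units; beyond the scatter) expected to lie beyond the scatter but short of the full gap to compound 1. The estimate for compound 3 is 2500 nM, within 600 nM to 8000 nM.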

Compound 3, inhibition constant: 5950 nM
The estimate for compound 3 lay 2.4-fold (0.38 log units) below the measured number; the measured number falls inside the stated range.
By their numbers in this assay, from the lowest: compound 1; then compounds 3 and 2 (each within the scatter of the next).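

In this assay, replacing phenyl with 5-methylfuran-2-yl on the saturated chain carbon bound to an amine nitrogen and a saturated chain carbon gives a 1.5-fold lower number from compound 2 to compound 3 (0.18 log units; within the scatter). On the core of compound 2, this position therefore does not separate the two aromatic rings, even though the exchange keeps the count of 6 heavy atoms and adds one hydrogen-bond acceptor. With the same 1-(5-methylfuran-2-yl)propyl group, compound 3 stands at 5950 nM and compound 1 at 234 nM, so this group on the core of compound 2 does not reproduce the number of compound 1, from which compound 3 differs only in the core; no supporting data explain either result.

Going by these compounds, whether the same exchange would read differently on the core of compound 1 remains open. Also open, on these data alone, is whether an unsubstituted furan-2-yl, a 5-methylthiophen-2-yl or a longer chain in place of the ethyl on this saturated carbon would move the number beyond the scatter.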